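A few compounds are considered here, and "the series" means these few. Any claim that something is new, unique, unknown or untested is made for them only; others in the source may bear on it.

Measured compounds:
- compound 1 `N=C(NCCCc1c[nH]cn1)NCCC(c1ccccn1)c1ccccc1F`; compound 1 gives 7.46 in a functional assay on cardiac atrium for agonist activity at histamine H2 receptor (Cavia porcellus); a higher number here means a more potent compound, by a factor of ten per unit of this negative logarithm, a lower number a less potent compound
- compound 2 `N=C(NCCCc1c[nH]cn1)NCCC(c1cc(F)cc(F)c1)c1ccccn1`; compound 2 gives 8.05 in this assay
- compound 3 `N=C(NCCCc1c[nH]cn1)NCCC(c1ccc(Cl)c(Cl)c1)c1ccccn1`; compound 3 gives 8.19 in this assay

Compound 3 stands highest of the three numbers. Its nearest neighbour is compound 2, separated by a number 0.14 log units higher from compound 2 to compound 3 (within the scatter), which lies within the scatter, so these two cannot be ranked against each other. Compound 1 lies furthest off: a number 0.73 log units higher from compound 1 to compound 3 (beyond the scatter), beyond the scatter, as is a number 0.59 log units higher from compound 1 to compound 2 (beyond the scatter).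

Compound 4 `N=C(NCCCc1c[nH]cn1)NCCC(c1ccccn1)c1ccccn1` is not yet measured. Relative to compound 3 the change is pyridin-2-yl in place of 3,4-dichlorophenyl on a saturated chain carbon bound to an aromatic carbon and a saturated chain carbon. For the measured compounds named here, no measured step bears on it directly: all three steps exchange one substituted phenyl for another substituted phenyl on the same chain carbon, and none exchanges that ring for a pyridin-2-yl. What the steps do show is that going from 2-fluorophenyl to 3,5-difluorophenyl or to 3,4-dichlorophenyl brought a modest gain, while the two disubstituted phenyls are indistinguishable. Removing the 3,4-dichlorophenyl altogether takes compound 4 off the path on which those gains were seen, so in this assay a modest drop back toward compound 1 is expected rather than a further rise. The step from compound 3 is estimated as a number 0.59 log units lower from compound 3 to compound 4 (beyond the scatter). For compound 4 the expected value is 7.6, with a range from 7 to 8.2.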

Compound 4, negative logarithm of the half-maximal effective concentration: 6.9
Compound 4: middle estimate off by 0.70 log units, on the high side; measured number below the stated range.
By their numbers in this assay, from the lowest: compound 4; then compound 1; then compounds 2 and 3 (each within the scatter of the next).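

Working notes: the earlier steps varied only the substituents on a phenyl ring, whereas compound 4 shows that the ring itself on this saturated chain carbon matters in this assay. Pyridin-2-yl gives a lower number than each of the three substituted phenyls, with large losses against the two disubstituted rings (a number 1.29 log units lower from compound 3 to compound 4 (beyond the scatter); a number 1.15 log units lower from compound 2 to compound 4 (beyond the scatter)) and a modest one against 2-fluorophenyl (a number 0.56 log units lower from compound 1 to compound 4 (beyond the scatter)), which leaves compound 4 the least potent of the four. No available evidence accounts for this loss.

The change from 3,4-dichlorophenyl to pyridin-2-yl both removes the chlorine atoms and brings in a ring nitrogen, so these compounds cannot show how much of the loss belongs to either part, and an unsubstituted phenyl on this chain carbon would be the comparison that separates them. Also open, on these data alone, is whether the loss is specific to pyridin-2-yl or extends to other ring forms, such as pyridin-3-yl or a thiophene, and whether a methoxy group on the phenyl ring would hold the number reached by the halogenated rings.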